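The compounds below may be only part of what the source reports. "The series", "measured", "known", "first", "only" and "open" are said of these compounds alone.

Compound 1 `NCC(N)CCc1c[nH]c2ccc(F)cc12` was tested in an assay on isolated protein (urine) for inhibition of Myeloperoxidase (Homo sapiens), with a stated time of 5 min (a higher number here means a weaker inhibitor, a lower number a stronger inhibitor), where compound 1 gives 60 nM. Going by the values given here, that is the only number in this set. Compound 2 `NCCCc1c[nH]c2ccc(C(=O)O)cc12` differs from compound 1 in more than one place, and in this assay compound 2 was reported as "not active" (no number reported), with no number behind it, so no comparison with compound 1 can be drawn from it. Compound 3 `NC(=O)CCc1c[nH]c2ccc(F)cc12` has not yet been measured. It differs from compound 1 by carbamoyl in place of 1,2-diaminoethyl on a saturated chain carbon, two bonds along the chain from an aromatic carbon. Among the compounds with values here, no measured pair shows this change, so only an expectation can be given. The whole 1,2-diaminoethyl group leaves and a smaller carbamoyl takes its place on the chain. The expected step of a 10-fold higher number from compound 1 to compound 3 (1.00 log units; beyond the scatter) is toward weaker inhibition, larger than the usual scatter. Compound 3 is therefore estimated to give 600 nM, with a likely range from 150 nM to 3000 nM.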

Compound 3, half-maximal inhibitory concentration: 132 nM
Compound 3: middle estimate off by 4.5-fold (0.66 log units), on the high side, and the stated range ends above it.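

The 1,2-diaminoethyl group of compound 1 is not essential for inhibition in this assay: replacing it with the smaller carbamoyl gives a 2.2-fold higher number from compound 1 to compound 3 (0.34 log units; beyond the scatter), a modest weakening. Going by these compounds alone, this is the first measured change at this saturated chain carbon, and it shows that inhibition survives when the whole group is exchanged, with the shared core and its fluorine left unchanged. No measurement at hand explains why the step is this size.

A single pair cannot show how far this position tolerates change, or whether other groups, such as a carboxylic acid or hydroxymethyl, would match or improve on compound 1. It also leaves open how a longer chain ending in carbamoyl would compare with compound 3.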